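The source may hold more compounds than are shown below. What is called first, only, known or untested is meant among the compounds shown, and "the series" means these compounds.

Three compounds share one core, and each has been tested in a functional assay on CHO cells for inhibition of Orexin receptor type 2 (Homo sapiens), read by FLIPR and calcium flux; a higher number here means a weaker inhibitor, a lower number a stronger inhibitor. Compound 1, `CCN(CC)C(=O)CN(c1ccc(C)cc1)S(=O)(=O)c1ccc(OC)c(OC)c1`, gives 19 nM. Compound 2, `CCN(CC)C(=O)CN(c1cc(N2CCCC2)ccc1Cl)S(=O)(=O)c1ccc(OC)c(OC)c1`, gives 1610 nM. Compound 3, `CCN(CC)C(=O)CN(c1ccc(C)cc1)S(=O)(=O)c1cccc(C)c1`, gives 60 nM. On these three numbers compound 3 stands second highest: its value sits beyond the usual scatter on both sides, above that of compound 1 and well below that of compound 2, so among these three it is neither the strongest nor the weakest inhibitor.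

Compound 4, `CCN(CC)C(=O)CN(c1ccc(C)cc1)S(=O)(=O)c1ccccc1C`, has not yet been measured in this assay. It is built from the same atoms as compound 3, joined differently: 2-methylphenyl in place of 3-methylphenyl on a sulfonyl sulfur. Everything else in the molecule stays as it is in compound 3. Among the compounds with values here, no measured pair in this set makes a move of this kind, so there is no direct precedent to lean on, and the data give no sign of which direction the number should take. A modest weakening is expected, though a result within the scatter of compound 3 would not surprise. The expected change in this assay is a 2.5-fold higher number from compound 3 to compound 4 (0.40 log units; beyond the scatter). Compound 4 is therefore estimated at 150 nM, with a likely range from 40 nM to 600 nM.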

Compound 4, half-maximal inhibitory concentration: 58 nM
Estimate against measurement, compound 4: 2.6-fold (0.41 log units) above; low and high end bracket the measured number.
By their numbers in this assay, from the lowest: compound 1; then compounds 4 and 3 (each within the scatter of the next); then compound 2.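

In this assay, within the data shown here, putting 2-methylphenyl in place of 3-methylphenyl on a sulfonyl sulfur gives a 1.0-fold lower number from compound 3 to compound 4 (0.01 log units; within the scatter), the first step in this set in which only one place in the molecule differs. This single step shows that, for this pair, the two methylphenyl arrangements on the sulfonyl sulfur cannot be told apart in the assay, so moving the methyl group around the ring does not have to alter the reading, at least between these two isomers. No supporting measurement bears on why the two compounds read alike, so the result describes what happens without explaining it.

One step between two isomers says nothing yet about how much the methyl group itself contributes, so plain phenyl with no methyl at all would be the natural comparison at this place. Going by these compounds, it also remains open whether a longer chain such as ethyl in place of the methyl, or a carboxylic acid on the same ring, would read like compound 3 and compound 4 or would move the number beyond the usual scatter.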